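The source may hold more compounds than are shown below. What is called first, only, known or untested is meant among the compounds shown, and "the series" means these compounds.

Measured compounds in an ADME assay on CHO-K1 cells (Cricetulus griseus) for cytotoxicity, read by MTT assay, with a stated time of 24 h; a lower number here means a stronger inhibitor, a higher number a weaker inhibitor:
compound 1 `CCCCCCCCCCCCCCCCCC(=O)Nc1nnc(S[C@@H]2O[C@H](COC(C)=O)[C@H](OC(C)=O)[C@H](OC(C)=O)[C@H]2OC(C)=O)s1` gives 44700 nM;
compound 2 `CCCCCCCC(=O)Nc1nnc(S[C@@H]2O[C@H](CO)[C@H](O)[C@H](O)[C@H]2O)s1` gives 60100 nM;
compound 3 `CCCCCCCCCCCCCCCC(=O)Nc1nnc(S[C@@H]2O[C@H](COC(C)=O)[C@H](OC(C)=O)[C@H](OC(C)=O)[C@H]2OC(C)=O)s1` gives 90400 nM.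

Compound 2 stands second highest of the three numbers; its gaps to compound 1 and to compound 3 are both within the scatter, so no order among them is claimed.

Compound 4 `C=CCCCCCCCCC(=O)Nc1nnc(S[C@@H]2O[C@H](CO)[C@H](O)[C@H](O)[C@H]2O)s1` differs from compound 2 by allyl in place of hydrogen on a saturated chain carbon, seven bonds along the chain from a carbonyl carbon.

Going by the values given here, the one measured step that bears on a change of chain length is a 2.0-fold higher number from compound 1 to compound 3 (0.31 log units; beyond the scatter), where the shorter chain gave the higher number. Extending the chain in compound 4 would, by that single step, point toward a lower number in this assay, but the step was only modest and the double bond has no precedent here. For compound 4 the expected step is a 1.5-fold lower number from compound 2 to compound 4 (0.18 log units; within the scatter). Compound 4 is therefore estimated at 40000 nM, with a range of 18000 nM to 95000 nM.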

Compound 4, half-maximal inhibitory concentration: "not active" (no number reported)
Nothing numeric was reported for compound 4; there is nothing to compare the estimate with.
By their numbers in this assay, from the lowest: compounds 1, 2 and 3 (each within the scatter of the next, the first and the last beyond it).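

Going by these compounds alone, compound 4 is recorded as not active in this assay with no number reported, so no step from compound 2 to compound 4 can be read. Nothing available explains this result. The compounds shown leave open how far allyl in place of hydrogen moves the number.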